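Notes on replacing tert-butyl with 2-hydroxyethyl

This account rests on a few compounds, and the source may have more. Where it says the series, first, only, none or still open, it means among the compounds named here.

Measured so far in a functional assay on K562 cells (Homo sapiens) for cytotoxicity, read by MTT assay, with a stated time of 48 h (a higher number here means a weaker inhibitor, a lower number a stronger inhibitor), are two compounds.
- compound 1 `CC(C)(C)OC(=O)/C=C/c1ccc2c(c1)C(=O)C(=O)N2Cc1ccc(Br)cc1` gives 290 nM
- compound 2 `COC(=O)/C=C/c1cccc2c1C(=O)C(=O)N2Cc1ccc(OC)cc1` gives 350 nM

Within the data shown here, the values of compound 1 and compound 2 lie within the scatter of each other, so these two numbers set no order between the compounds.

Compound 3 `O=C(/C=C/c1ccc2c(c1)C(=O)C(=O)N2Cc1ccc(Br)cc1)OCCO` carries 2-hydroxyethyl in place of tert-butyl on an oxygen next to a carbonyl group, and the counted difference reads 2-hydroxyethyl in place of tert-butyl on an oxygen next to a carbonyl group in full.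

Among the measured compounds shown here, no two measured compounds differ in one place only, so the data offer no direct precedent for this change. In this assay a moderate move toward a higher number, meaning a weaker inhibitor, is expected, although a result within the scatter remains possible. The expected size is given by a 1.6-fold higher number from compound 1 to compound 3 (0.19 log units; within the scatter) as an estimate with wide margins. The starting point for this expectation is compound 1 at 290 nM and nothing firmer. For compound 3 the expected value is 450 nM with an estimated range from 150 nM to 1300 nM for repeated measurements.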

Compound 3, half-maximal inhibitory concentration: 50 nM
Compound 3: middle estimate off by 9.0-fold (0.95 log units), on the high side; the measured number lies below the stated range.
By their numbers in this assay, from the lowest: compound 3; then compounds 1 and 2 (each within the scatter of the next).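

In this assay, among these compounds, the pair of compound 1 and compound 3 gives the first single-place comparison: 2-hydroxyethyl in place of tert-butyl on an oxygen next to a carbonyl group brings a 5.8-fold lower number from compound 1 to compound 3 (0.76 log units; beyond the scatter), so the group at this oxygen does affect the number, which compounds 1 and 2 could not show because they differ in more than one place. The change removes a group of four carbon atoms with no hydrogen-bond donor or acceptor and brings in one with one of each, and the lower number shows that tert-butyl is not required here for activity in this assay. Nothing available bears on why the number falls.

This single pair does not separate the loss of tert-butyl from the gain of the hydroxyl group, a question that 2-methoxyethyl or a plain ethyl group at the same oxygen would address. Also open, as far as these compounds go, are how a longer chain such as 3-hydroxypropyl, an amine such as 2-aminoethyl or a free carboxylic acid would read, and whether the step carries over to the core of compound 2.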